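This account rests on a few compounds, and the source may have more. Where it says the series, first, only, none or still open, it means among the compounds named here.

In a functional assay on HepG2 cells (Homo sapiens) for cytotoxicity, read by MTT assay, with a stated time of 24 h (a higher number here means a weaker inhibitor, a lower number a stronger inhibitor), compound 1 `O=C1/C(=C/c2ccncc2)CN(S(=O)(=O)c2ccccc2)C/C1=C\c1ccccc1C(F)(F)F` gives 7020 nM, compound 2 `O=C1/C(=C/c2ccncc2)CN(S(=O)(=O)c2ccc([N+](=O)[O-])cc2)C/C1=C\c1ccccc1C(F)(F)F` gives 13400 nM and compound 3 `O=C1/C(=C/c2ccncc2)CN(S(=O)(=O)c2ccc(Cl)cc2)C/C1=C\c1ccccc1C(F)(F)F` gives 7190 nM. Compound 3 therefore stands within the scatter of both others. Compound 4 `O=C1/C(=C/c2ccncc2)CN(S(=O)(=O)c2ccc(Br)cc2)C/C1=C\c1ccccc1C(F)(F)F` differs from it by one swap, bromo in place of chloro on an aromatic carbon, para to a large group. The nearest evidence is the same position changing from hydrogen to chloro, a 1.0-fold higher number from compound 1 to compound 3 (0.01 log units; within the scatter). Placing nitro there gave a 1.9-fold higher number from compound 1 to compound 2 (0.28 log units; within the scatter), and replacing that nitro with chloro gave a 1.9-fold lower number from compound 2 to compound 3 (0.27 log units; within the scatter). None of these steps leaves the scatter, so none is expected here. The expected result is a 1.0-fold higher number from compound 3 to compound 4 (0.02 log units; within the scatter). Compound 4 is estimated at 7500 nM, with an expected range from 4000 nM to 14000 nM.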

Compound 4, half-maximal inhibitory concentration: 14500 nM
Estimate against measurement, compound 4: 1.9-fold (0.29 log units) below; the whole stated range lies below it.
By their numbers in this assay, from the lowest: compounds 1, 3, 2 and 4 (each within the scatter of the next, the first and the last beyond it).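

In this assay, for the compounds shown here, no step at this position had left the scatter until bromo gave one over hydrogen (a 2.1-fold higher number from compound 1 to compound 4 (0.32 log units; beyond the scatter)), a modest change. Chloro to bromo stays within the scatter (a 2.0-fold higher number from compound 3 to compound 4 (0.30 log units; within the scatter)), and so does nitro to bromo (a 1.1-fold higher number from compound 2 to compound 4 (0.03 log units; within the scatter)), so bromo cannot be separated from either group. Nothing measured here explains why bromo, but not chloro, moves beyond the scatter from hydrogen.
On these data alone, it remains open whether an amine or a methoxy group at this position would stay close to hydrogen and chloro or to nitro and bromo.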